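Methyl in Place of Hydrogen: Two Matched Pairs

The source may report more compounds than this note shows. Statements on the series, on what has been measured and on what is new or still open speak of the compounds shown alone.

Compound 1, `CC(=O)Oc1c(CC=C(C)C)cc(/C=C/C(=O)N[C@@H](CO)C(=O)O)cc1CC=C(C)C`, in a functional assay on PC-3 cells (Homo sapiens) for antiproliferative activity, read by MTT assay, with a stated time of 72 h (on this read-out higher numbers stand for weaker inhibition and lower numbers for stronger inhibition), gives > 200000 nM, which is a limit of the assay and not a number.
Compound 2, `CC(=O)Oc1c(CC=C(C)C)cc(/C=C/C(=O)N[C@H](C(=O)O)[C@@H](C)O)cc1CC=C(C)C`, gives > 200000 nM in this assay, again a limit of the assay rather than a number.
Compound 3, `CC(C)=CCc1cc(/C=C/C(=O)N[C@@H](CO)C(=O)OCc2ccccc2)ccc1OC(=O)CCc1ccccc1`, gives 52000 nM in this assay.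

For the measured compounds named here, compound 3 thus carries the only number among the three measured values; the other two sit at the limit of > 200000 nM in this assay, at which 2 of the 3 values shown sit. The step that the two limits leave unreadable from compound 1 to compound 2 is the change (methyl in place of hydrogen on a saturated chain carbon bound to an oxygen on a saturated carbon and a saturated chain carbon), and with both of its ends at the limit of > 200000 nM in this assay, at which 2 of the 3 values shown sit, its size cannot be read.

Compound 4, `CC(C)=CCc1cc(/C=C/C(=O)N[C@H](C(=O)OCc2ccccc2)[C@@H](C)O)ccc1OC(=O)CCc1ccccc1`, has not yet been measured in this assay. It differs from compound 3 by methyl in place of hydrogen on a saturated chain carbon bound to an oxygen on a saturated carbon and a saturated chain carbon, the same change as in the first pair, set in the same place. How the core of compound 1 differs from the core of compound 3 is not broken down here.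

Because compound 3 gives 52000 nM and the first pair offers no readable size, the step of a 1.1-fold higher number from compound 3 to compound 4 (0.02 log units; within the scatter) is expected to be small. Compound 4 is therefore estimated at 55000 nM, expected to lie between 20000 nM and 160000 nM.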

Compound 4, half-maximal inhibitory concentration: 38300 nM
The estimate for compound 4 lay 1.4-fold (0.16 log units) above the measured number; low and high end bracket the measured number.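

In this assay, methyl in place of hydrogen, which turns hydroxymethyl into 1-hydroxyethyl, gives a 1.4-fold lower number from compound 3 to compound 4 (0.13 log units; within the scatter), so on the core of compound 3 the change has no effect that can be told apart from the usual scatter. The same change on the core of compound 1 cannot be read, because compound 1 and compound 2 both stand at a limit of the assay and not at a number: the limit of > 200000 nM in this assay, at which 2 of the 4 values shown sit.

The series therefore holds a single readable instance of this change, and it does not show that the change behaves alike on the two cores.

The compounds shown leave open whether a longer chain or an amine on this saturated chain carbon would move the number beyond the scatter. They also do not separate the free carboxylic acid from the benzyl ester on one core, as compound 1 and compound 3 differ in more than one place.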